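This account rests on a few compounds, and the source may have more. Where it says the series, first, only, none or still open, it means among the compounds named here.

Measured in a functional assay on HeLa cells (Homo sapiens) for inhibition, read by CCK-8 assay, with a stated time of 72 h, tested at 8 uM; a higher number here means more inhibition of growth at the concentration tested, a lower number less inhibition of growth:
Compound 1 `Nc1ccccc1NC(=O)/C=C/c1ccc(CSc2ccc(Cl)cc2)cc1`: 17.3%
Compound 2 `Cc1ccc(SCc2ccc(/C=C/C(=O)Nc3ccccc3N)cc2)cc1`: 21.7%
Compound 3 `Nc1ccccc1NC(=O)/C=C/c1ccc(CSc2ccc(F)cc2)cc1`: 10.4%

Compound 3, at 10.4%, lies within the scatter of compound 1 and clearly under compound 2, with a number 11.3 percentage points lower from compound 2 to compound 3 (beyond the scatter). Compound 4 `Nc1ccccc1NC(=O)/C=C/c1ccc(CSc2cccc3ccccc23)cc1` carries naphthalen-1-yl in place of 4-fluorophenyl on a sulfur. The nearest evidence comes from single-substituent swaps on the ring that this change removes: a number 6.9 percentage points lower from compound 1 to compound 3 (within the scatter), a number 4.4 percentage points higher from compound 1 to compound 2 (within the scatter), and the step from compound 2 to compound 3 already given. None of them replaces the ring itself, so they bear on the change only loosely. A modest rise is expected, comparable in size to the largest of these steps but uncertain. The expected step is a number 10.6 percentage points higher from compound 3 to compound 4 (beyond the scatter). Compound 4 is estimated at 21%, within a range of 7% to 40%.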

Compound 4, percent growth inhibition at one concentration: 22.1%
Compound 4: the middle estimate sits 1.1 percentage points below what was measured; the measured number falls inside the stated range.
By their numbers in this assay, from the lowest: compounds 3, 1, 2 and 4 (each within the scatter of the next, the first and the last beyond it).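

In this assay, the first replacement of the whole ring on the sulfur gives a number 11.7 percentage points higher from compound 3 to compound 4 (beyond the scatter), yet a number 0.4 percentage points higher from compound 2 to compound 4 (within the scatter) and a number 4.8 percentage points higher from compound 1 to compound 4 (within the scatter). Naphthalen-1-yl, with its 2 six-membered aromatic rings, therefore separates only from 4-fluorophenyl and not from 4-methylphenyl or 4-chlorophenyl, so a second ring is tolerated here without a step beyond the scatter from those two compounds. Nothing available explains the step from the fluorinated compound. Going by these compounds, it remains open whether naphthalen-2-yl, benzyl or a plain butyl chain on the sulfur would give a similar number.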